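A few compounds are considered here, and "the series" means these few. Any claim that something is new, unique, unknown or untested is made for them only; others in the source may bear on it.

Compound 1 `O=C(CCCCC(S)CCS)Nc1ccc(OC(F)(F)F)cc1`: 15%
Compound 2 `O=C(CCCCC(S)CCS)Nc1cccc2ccccc12`: "not active" (no number reported)
Compound 3 `CC(=O)SCCC(CCCCC(=O)Nc1ccccc1)SC(C)=O`: 2.5%

All three compounds were tested in a functional assay on KB cells (Homo sapiens) for inhibition, read by MTT assay, with a stated time of 24 h, tested at 10 ug/mL; on this read-out lower numbers stand for less inhibition of growth and higher numbers for more inhibition of growth at the one concentration tested. Of the two compounds with a number, compound 3 stands lowest at 2.5%, while compound 1 reads 15%, a gap beyond the usual scatter. Compound 2 has no number and was reported as "not active" (no number reported). Growth inhibition is therefore weak wherever a number exists, and compound 3 sits close to the bottom of the scale.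

The next compound, compound 4 `CC(=O)SCCC(CCCCC(=O)Nc1cccc(Cl)c1)SC(C)=O`, keeps the structure of compound 3 except in one place, where phenyl becomes 3-chlorophenyl. This puts chloro in place of hydrogen on an aromatic carbon. Going by the values given here, no measured pair in this set isolates that change, so the data give no direct guide to its size. Compound 3 at 2.5% leaves little room for a fall, so any visible movement is expected to be upward. The estimated change is small, a number 4.5 percentage points higher from compound 3 to compound 4 (within the scatter), and is expected to stay within the scatter. Compound 4 is expected to give about 7%, with an estimated range of 0% to 20%.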

Compound 4, percent growth inhibition at one concentration: "not active" (no number reported)
Compound 4: no number reported; the estimate stays without a comparison.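

Compound 4 is reported in this assay as "not active" (no number reported), and without a number for it, the step from compound 3 to compound 4 cannot be read. No outside information bears on this result. The compounds shown leave open how large a change, if any, chloro in place of hydrogen on an aromatic carbon brings to growth inhibition.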